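Guanidine series: chain extension versus an inserted chain amine

This account rests on a few compounds, and the source may have more. Where it says the series, first, only, none or still open, it means among the compounds named here.

Measured so far:
compound 1 `CC(C)=CCNC(=N)NCCCCCN`: 10 nM
compound 2 `CC(C)=CCNC(=N)NCCCCCCN`: 22 nM

Among the compounds with values here, in an assay on isolated protein for inhibition of polyamine oxidase 1 (Zea mays), read by spectrophotometry, using a Dixon plot, at pH 6.5 (on this read-out lower numbers stand for stronger inhibition and higher numbers for weaker inhibition), compound 2 gives 22 nM, the highest of the two numbers; the single step of a 2.2-fold higher number from compound 1 to compound 2 (0.34 log units; beyond the scatter) is modest. Compound 3 `CC(C)=CCNC(=N)NCCCNCCCN` carries (3-aminopropyl)amino in place of 3-aminopropyl on a saturated chain carbon, three bonds along the chain from an amine nitrogen. Within the data shown here, the only measured step concerns chain length, not a nitrogen within the chain, so it bears on this change loosely at best. The expected step of a 1.1-fold lower number from compound 2 to compound 3 (0.04 log units; within the scatter) is therefore none beyond the scatter, held with a wide range. Compound 3 is estimated at 20 nM, between 5 nM and 80 nM.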

Compound 3, inhibition constant: 1210 nM
For compound 3 the middle estimate is 61-fold (1.78 log units) below the measured one; the measured number lies above the stated range.
By their numbers in this assay, from the lowest: compound 1; then compound 2; then compound 3.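

In this assay, the chain tolerated lengthening with only a modest loss (a 2.2-fold higher number from compound 1 to compound 2 (0.34 log units; beyond the scatter)), but (3-aminopropyl)amino in place of 3-aminopropyl, on a saturated chain carbon, gives a large rise (a 55-fold higher number from compound 2 to compound 3 (1.74 log units; beyond the scatter)). The step to the shorter-chain compound is large as well (a 120-fold higher number from compound 1 to compound 3 (2.08 log units; beyond the scatter)), so at this position the inserted chain amine matters far more than chain length among these compounds. Nothing at hand explains the loss.

Open, going by these compounds, is whether an ether oxygen at the same place in the chain would give the same loss, which would separate the effect of an amine from that of any inserted atom. Also open, on these data alone, is whether a longer chain carrying the inserted amine would behave as compound 3 does.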